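Aryloxy swap at the chain end of compound 1

This account rests on a few compounds, and the source may have more. Where it says the series, first, only, none or still open, it means among the compounds named here.

Compound 1 `COc1ccc(OCCCCCN2CCCC(COC(=O)c3ccccc3N3C(=O)CC(C)C3=O)C2)cc1OC` gives the highest number of the three measured in an in vitro functional assay on HEK ts201 cells for antagonist activity at Neuronal acetylcholine receptor; alpha3/beta4 (Homo sapiens), read by fluorescence and calcium flux (on this read-out higher numbers stand for weaker inhibition and lower numbers for stronger inhibition), at 2000000 nM. Compound 2 `O=C(NCc1ccccc1-c1ccccc1)C1CCCN(CCCc2ccccc2)C1` gives 14500 nM in this assay, and compound 3 `O=C(OC1CCCN(C(=O)CCc2ccccc2)C1)c1ccccc1-c1ccccc1` gives 6000 nM; both stand well below compound 1, beyond the scatter. Within the data shown here, these three differ in too many places for any single change to be read off, so no step between measured compounds is available. Compound 4 `CC1CC(=O)N(c2ccccc2C(=O)OCC2CCCN(CCCCCOc3ccc(Cl)c(Cl)c3)C2)C1=O` keeps the core of compound 1 and carries 3,4-dichlorophenyl in place of 3,4-dimethoxyphenyl on an oxygen on a saturated carbon. Among the measured compounds shown here, no measured pair shows this change. From compound 1, a modest move toward a lower number is expected, a 4.0-fold lower number from compound 1 to compound 4 (0.60 log units; beyond the scatter), with a wide range. Compound 4 is therefore estimated at 500000 nM in this assay, within 50000 nM to 3000000 nM.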

Compound 4, half-maximal inhibitory concentration: 9120 nM
Beside the measured number, compound 4's estimate is 55-fold (1.74 log units) above it; measured number outside the range, below it.
By their numbers in this assay, from the lowest: compounds 3, 4 and 2 (each within the scatter of the next, the first and the last beyond it); then compound 1.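

In this assay, this position proves highly sensitive to the aryl group: 3,4-dichlorophenyl in place of 3,4-dimethoxyphenyl on an oxygen on a saturated carbon gives a 220-fold lower number from compound 1 to compound 4 (2.34 log units; beyond the scatter) with the rest of compound 1 unchanged. Among these compounds, the earlier compounds offered no single-place comparison, so this is the first direct reading of this position. Nothing at hand accounts for the size of this step. Open, going by these compounds, is whether one chlorine alone, at either place on the ring, carries the step, and how 3,4-difluorophenyl or unsubstituted phenyl compares.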